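Trifluoromethyl for Fluoro on a Weakly Cytotoxic Core

This account rests on a few compounds, and the source may have more. Where it says the series, first, only, none or still open, it means among the compounds named here.

Of the compounds shown here, three sharing one core have been measured in a functional assay on FM3A cells (Mus musculus) for cytotoxicity, read by cell counting, with a stated time of 2 days; a higher number here means a weaker inhibitor, a lower number a stronger inhibitor. Compound 1 `CC(C)(C)c1ccc(CN2C(=O)S/C(=C\c3cccc(N)c3)C2=O)cc1` gives 188000 nM. Compound 2 `Nc1cccc(/C=C2\SC(=O)N(Cc3ccc(F)cc3)C2=O)c1` gives 140000 nM, and compound 3 `Nc1cccc(/C=C2\SC(=O)N(Cc3cccc(Cl)c3)C2=O)c1` gives 164000 nM. Compound 2 carries the lowest of the three numbers, yet the step of a 1.3-fold lower number from compound 1 to compound 2 (0.13 log units; within the scatter) and the step of a 1.2-fold higher number from compound 2 to compound 3 (0.07 log units; within the scatter) both lie within the scatter, so none of the three can be set apart from the others.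

Compound 4 `Nc1cccc(/C=C2\SC(=O)N(Cc3ccc(C(F)(F)F)cc3)C2=O)c1` has not been measured. It differs from compound 2 by trifluoromethyl in place of fluoro on an aromatic carbon. The step that bears on it most directly is a 1.3-fold lower number from compound 1 to compound 2 (0.13 log units; within the scatter), where tert-butyl against fluoro on an aromatic carbon of this same ring moved the number only within the scatter; the step of a 1.2-fold higher number from compound 2 to compound 3 (0.07 log units; within the scatter) likewise changed the substituent on this ring without an effect beyond the scatter. Compound 4 is therefore expected to give 150000 nM, with a range from 70000 nM to 320000 nM. The step of a 1.1-fold higher number from compound 2 to compound 4 (0.03 log units; within the scatter) is expected to stay within the scatter.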

Compound 4, half-maximal inhibitory concentration: > 250000 nM
Compound 4 was reported as a limit (the forecaster's own chance of this, stated with the estimate: 5%); middle value at least 1.6-fold (0.22 log units) from the limit.
By their numbers in this assay, from the lowest: compounds 2, 3 and 1 (each within the scatter of the next). At a limit, above all of these: compound 4.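

In this assay compound 4 is reported only as a limit, > 250000 nM. The change to trifluoromethyl gives an at least 1.7-fold higher number from compound 2 to compound 4 (0.25 log units; that floor lies within the scatter), and the comparison with tert-butyl gives an at least 1.3-fold higher number from compound 1 to compound 4 (0.12 log units; that floor lies within the scatter), so neither floor sets trifluoromethyl apart at this aromatic carbon, although the true gaps may be larger. What the earlier compounds did not show is that a change at this position can leave the read-out without a definite number, as compound 4 is the only one of the four reported this way: the limit of > 250000 nM in this assay, at which 1 of the 4 values shown sits.

The compounds shown do not tell how far compound 4 truly lies from compound 1 or compound 2. They also leave open whether an amine or a carboxylic acid on this aromatic carbon would move the number beyond the scatter.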